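A few compounds are considered here, and "the series" means these few. Any claim that something is new, unique, unknown or untested is made for them only; others in the source may bear on it.

Two compounds of the series have been run in a functional assay on LNCaP cells (Homo sapiens) for cytotoxicity, read by MTT assay, with a stated time of 72 h; a higher number here means a weaker inhibitor, a lower number a stronger inhibitor. Among the measured compounds shown here, compound 1 `COc1cccc(/C(=C\c2cn(C(C)=O)c3ccc(OCc4ccccc4)cc23)C(=O)O)c1` gives 65100 nM, the only number in this assay so far. Compound 2 `CC(=O)n1cc(/C=C(/C(=O)O)c2ccccc2)c2cc(OCc3ccccc3)ccc21` gives only a limit, > 100000 nM, which is the limit of > 100000 nM in this assay, at which 1 of the 2 values shown sits. For the measured compounds named here, the one measured step, an at least 1.5-fold higher number from compound 1 to compound 2 (0.18 log units; that floor lies within the scatter), removes the methoxy group. Compound 3 `COc1cc(OC)cc(/C(=C\c2cn(C(C)=O)c3ccc(OCc4ccccc4)cc23)C(=O)O)c1` differs from compound 1 in that (methoxy in place of hydrogen on an aromatic carbon). Going by the values given here, only the step from compound 1 to compound 2 bears on this change, and its floor lies within the scatter. No step beyond the scatter is therefore expected in this assay. Compound 3 is expected to show a 1.3-fold lower number from compound 1 to compound 3 (0.11 log units; within the scatter), with an estimate of 50000 nM from 20000 nM to 100000 nM.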

Compound 3, half-maximal inhibitory concentration: 26100 nM
Beside the measured number, compound 3's estimate is 1.9-fold (0.28 log units) above it; the measured number falls inside the stated range.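

Among the compounds shown here, a second methoxy group on the aromatic ring, giving 3,5-dimethoxyphenyl, produces the first step beyond the scatter at this position in this assay: a 2.5-fold lower number from compound 1 to compound 3 (0.40 log units; beyond the scatter). Against the unsubstituted phenyl the step is an at least 3.8-fold lower number from compound 2 to compound 3 (0.58 log units; beyond the scatter), and its true size stays unknown. Compound 2 gives a limit, not a number: the limit of > 100000 nM in this assay, at which 1 of the 3 values shown sits.

From the compounds shown here alone, whether the lower number follows from the count of methoxy groups or from their placement remains open. So does whether a hydroxy group or an ethoxy chain at the same place would give a similar step.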